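A few compounds are considered here, and "the series" means these few. Any claim that something is new, unique, unknown or untested is made for them only; others in the source may bear on it.

In an in vitro ADME assay on microsomes from liver (Simiiformes) (on this read-out higher numbers stand for a longer-lived compound and lower numbers for a shorter-lived compound), compound 1 `Cc1cc(CCCOc2c(C)cc(-c3noc(C)n3)cc2C)on1` gives 0.45 h. Compound 2 `CCOCc1cc(CCCOc2c(C)cc(-c3noc(C(F)(F)F)n3)cc2C)on1` reads > 2.5 h, which is a limit of the assay and not a number. Compound 3 `COCc1cc(CCCOc2c(C)cc(-c3noc(C4CC4)n3)cc2C)on1` also reads only a limit, > 2.5 h. From the compounds shown here alone, compound 2 therefore stands at the limit of > 2.5 h in this assay, at which 2 of the 3 values shown sit, and its true value remains open.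

Compound 4 `Cc1cc(-c2noc(C(F)(F)F)n2)cc(C)c1OCCCc1cc(CS(C)(=O)=O)no1` departs from compound 2 at one place, with methylsulfonyl in place of ethoxy on a saturated chain carbon bound to an aromatic carbon. Within the data shown here, no pair of measured compounds isolates this change, so the expectation rests on the limit of compound 2 alone. A change of this kind is not expected to shift the result in either direction beyond the scatter, and the estimated step is a step that the limit leaves unreadable from compound 2 to compound 4. The range is kept wide on the short-lived side, as compound 1 shows a value of 0.45 h in this assay. Compound 4 is expected to give about 3 h, within an estimated range of 1.2 h to 7 h.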

Compound 4, half-life: > 2.5 h
Compound 4: no number, only a limit (the forecaster's own chance of this, stated with the estimate: 55%); the middle value does not contradict the limit.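

Among these compounds, compound 2 and compound 4 both read only a limit in this assay and not a number, so no step between them can be read. The compounds shown leave open the true half-life of each, and whether methylsulfonyl in place of ethoxy changes it at all.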